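Compound 4: methyl for cyclopropyl on the ring nitrogen

The compounds below may be only part of what the source reports. "The series", "measured", "known", "first", "only" and "open" are said of these compounds alone.

In an in vitro ADME assay on microsomes from liver (Rattus norvegicus) for metabolic stability, read by LC-MS, using NADPH, tested at 1 uM (on this read-out higher numbers stand for a longer-lived compound and lower numbers for a shorter-lived compound), compound 3 (`O=C1CN(Cc2ccc(-c3cccc(CN4CCCCC4)n3)cc2)C(=O)N1C1CC1`) gives 1.42 h as its half-life, and compound 2 (`CCN1C(=O)CN(Cc2ccc(-c3cccc(CN4CCCCC4)n3)cc2)C1=O`) gives 0.95 h which lies within the scatter of it. Compound 3 thus shares the upper end of the three numbers with compound 2. Going by the values given here, compound 1 (`O=C1CN(Cc2ccc(-c3ccc(F)c(CN4CCCCC4)n3)cc2)C(=O)N1CC1CC1`) gives 0.2 h as a clearly lower number than those two, and no single-place step ties it to either of them, so it offers no direct guide here.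

The step to compound 4 (`CN1C(=O)CN(Cc2ccc(-c3cccc(CN4CCCCC4)n3)cc2)C1=O`) puts methyl in place of cyclopropyl on an amide-type nitrogen in a ring and leaves the rest of the structure unchanged.

Among the compounds with values here, the only measured step at this place is a 1.5-fold higher number from compound 2 to compound 3 (0.17 log units; within the scatter) and it exchanges ethyl for cyclopropyl. Within the data shown here, that single step stays within the scatter, and no measured compound yet carries methyl at this place, so the evidence is thin. No shift beyond the scatter is expected in either direction. The estimated step is a 1.2-fold lower number from compound 3 to compound 4 (0.07 log units; within the scatter) and it is expected to remain within the scatter. For compound 4 the estimate is 1.2 h with an expected range from 0.6 h to 2.4 h in this assay when measured.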

Compound 4, half-life in the Rattus norvegicus assay: 1.5 h
Beside the measured number, compound 4's estimate is 1.3-fold (0.10 log units) below it, within the range that was stated.
By their numbers in the Rattus norvegicus assay, from the lowest: compound 1; then compounds 2, 3 and 4 (each within the scatter of the next).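

In the Rattus norvegicus assay this amide-type nitrogen in a ring now has three groups with readings, and methyl adds little to the picture of the earlier pair: the steps are a 1.1-fold higher number from compound 3 to compound 4 (0.02 log units; within the scatter) and a 1.6-fold higher number from compound 2 to compound 4 (0.20 log units; within the scatter), and both stay within the scatter, as does the step between ethyl and cyclopropyl, a 1.5-fold higher number from compound 2 to compound 3 (0.17 log units; within the scatter). Going from cyclopropyl, with its 3 heavy atoms and three-membered ring, to methyl, with 1 heavy atom and no ring, therefore leaves the half-life without a readable shift, so among compound 2, compound 3 and compound 4 no order by group size can be drawn at this place. In a physicochemical assay for lipophilicity (a higher number here means a more lipophilic compound, a lower number a more polar compound), compound 3 gives 1.6 and compound 4 gives 1.3; the same exchange gives a number 0.30 log units lower from compound 3 to compound 4 (within the scatter), also within the scatter, and no supporting data at hand explain either reading.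

Going by these compounds, whether a longer chain such as butyl, a carboxylic acid or an amine on this nitrogen would move the half-life beyond the scatter remains open. On these data alone, compound 1 differs from these compounds in more than one place, so which of its differences goes with its lower number also remains open.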